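The source may report more compounds than this note shows. Statements on the series, on what has been measured and on what is new or still open speak of the compounds shown alone.

Compound 1 `O=C(Nc1cccc(OCCc2ccccn2)c1)C1CCCN(C(=O)c2cc(C(F)(F)F)cc(C(F)(F)F)c2)C1` gives 5% in an ADME assay on PC-3 cells (Homo sapiens) for cytotoxicity, read by WST assay, tested at 100 uM; a higher number here means more inhibition at the concentration tested (going by the name of the read-out), a lower number less inhibition.
Compound 2 `CS(=O)(=O)c1cccc(C(=O)N2CCCC(C(=O)Nc3ccc(Cl)cc3)C2)c1` gives 2% in this assay.
Compound 3 `COCc1cccc(C(=O)N2CCCC(C(=O)Nc3ccc(Cl)cc3)C2)c1` gives 0% in this assay.

All three measured compounds show little inhibition in this assay. Compound 1 stands nearest to compound 2 and furthest from compound 3, yet both gaps lie within the usual scatter, so the three numbers cannot be told apart. The only measured step, a number 2 percentage points lower from compound 2 to compound 3 (within the scatter), changes a group on the aromatic ring attached to the carbonyl of the shared core and stays within the scatter, which suggests that this assay is insensitive to changes of this kind in the series.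

Compound 4 `Cn1cnnc1-c1cccc(NC(=O)C2CCCN(C(=O)c3cc(C(F)(F)F)cc(C(F)(F)F)c3)C2)c1` carries a different change on the other aromatic ring: 4-methyl-4H-1,2,4-triazol-3-yl in place of 2-(pyridin-2-yl)ethoxy on an aromatic carbon. The step from compound 2 to compound 3 bears on it only loosely, since it sits elsewhere, but nothing in the data points to a change beyond the scatter. The step of a number 1 percentage points lower from compound 1 to compound 4 (within the scatter) is therefore expected to be small. Compound 4 is estimated at 4%, with a range from 0% to 15%.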

Compound 4, a percentage reported as inhibition, at one concentration (the size of the read-out at that concentration, not a potency): 0%
Compound 4: the middle estimate sits 4 percentage points above what was measured, within the range that was stated.
By their numbers in this assay, from the lowest: compounds 3, 4, 2 and 1 (each within the scatter of the next).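

Swapping 2-(pyridin-2-yl)ethoxy for 4-methyl-4H-1,2,4-triazol-3-yl on the aromatic carbon meta to a large group gives a number 5 percentage points lower from compound 1 to compound 4 (within the scatter) in this assay. Going by these compounds alone, this is the first measured change at this position, and it is a large one: a chain of 9 heavy atoms ending in a six-membered aromatic ring gives way to a five-membered aromatic ring of 6 heavy atoms with 3 hetero atoms, yet the two numbers cannot be told apart. No measured property of these compounds bears on this result.

As far as these compounds go, whether any group at this position can move the number beyond the scatter stays open. A primary amine or a carboxylic acid on the same aromatic carbon, for example, would test whether a charged group behaves differently from these two uncharged ones.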